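Sulfonyl to sulfanyl on the pentafluorophenyl enone

The compounds below may be only part of what the source reports. "The series", "measured", "known", "first", "only" and "open" are said of these compounds alone.

Four compounds share an enone bearing a 4-chlorophenyl ketone. Compound 2 `Cc1ccc(S(=O)(=O)/C(=C/c2ccc(Oc3ccccc3)cc2)C(=O)c2ccc(Cl)cc2)cc1` and compound 3 `Cc1ccc(S/C(=C/c2ccc(Oc3ccccc3)cc2)C(=O)c2ccc(Cl)cc2)cc1` carry a phenoxyphenyl arm; compound 1 `Cc1ccc(S(=O)(=O)/C(=C/c2c(F)c(F)c(F)c(F)c2F)C(=O)c2ccc(Cl)cc2)cc1` and compound 4 `Cc1ccc(S/C(=C/c2c(F)c(F)c(F)c(F)c2F)C(=O)c2ccc(Cl)cc2)cc1` carry a pentafluorophenyl arm. How the cores of compound 1 and compound 2 differ is not broken down here.

In a functional assay on DU-145 cells (Homo sapiens) for inhibition, read by trypan blue exclusion, with a stated time of 96 h (a higher number here means a weaker inhibitor of growth, a lower number a stronger inhibitor of growth), compound 2 gives 1000 nM. In this assay compound 3 gives 10000 nM. The change (4-methylphenyl)sulfanyl in place of (4-methylphenyl)sulfonyl on a double-bonded chain carbon bound to a carbonyl carbon and a double-bonded chain carbon thus gave a 10-fold higher number from compound 2 to compound 3 (1.00 log units; beyond the scatter), a loss of growth inhibition.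

Compound 1 in this assay gives only a limit, > 100000 nM. That sits at the limit of > 100000 nM in this assay, at which 1 of the 3 values shown sits.

Compound 4 is not yet measured. It differs from compound 1 by (4-methylphenyl)sulfanyl in place of (4-methylphenyl)sulfonyl on a double-bonded chain carbon bound to a carbonyl carbon and a double-bonded chain carbon, the same kind of change as from compound 2 to compound 3. The expectation is a step that the limit leaves unreadable from compound 1 to compound 4 for compound 4, a step in the same direction as the measured one, because a 10-fold higher number from compound 2 to compound 3 (1.00 log units; beyond the scatter) was a loss and because compound 1 already sits at the limit of > 100000 nM in this assay, at which 1 of the 3 values shown sits. Since compound 1 gives only a limit, the size of the step cannot be fixed, and compound 4 is most likely to return a limit as well.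

The estimate for compound 4 in this assay is 300000 nM. The expected range for compound 4 runs from 50000 nM to 3000000 nM.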

Compound 4, concentration for 50% growth inhibition: 25000 nM
For compound 4 the middle estimate is 12-fold (1.08 log units) above the measured one, and the stated range ends above it.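

In this assay, replacing (4-methylphenyl)sulfonyl with (4-methylphenyl)sulfanyl does not carry over from one core to the other, and even the direction of the step reverses: the same change on two cores in this assay, a 10-fold higher number (1.00 log units; beyond the scatter) from compound 2 to compound 3 and an at least 4.0-fold lower number (0.60 log units; beyond the scatter) from compound 1 to compound 4, at least 40-fold (1.60 log units) apart, beyond the scatter of two such steps

With the pentafluorophenyl arm, the change brings a gain in growth inhibition, with an at least 4.0-fold lower number from compound 1 to compound 4 (0.60 log units; beyond the scatter), but the full size of that step stays unread, as its starting value is the limit held by compound 1: the limit of > 100000 nM in this assay, at which 1 of the 4 values shown sits.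

The two pairs show that the outcome of this change on the double-bonded chain carbon depends on the core, so a step measured on one core is a poor guide to the other, but they do not show which feature of the cores is responsible or how the change would behave on any further core.

Going by these compounds, it remains open whether a plain phenyl or a 4-methoxyphenyl arm would follow the loss from compound 2 to compound 3 or the gain from compound 1 to compound 4. Also open, on these data alone, is where a (4-methylphenyl)sulfinyl group at the same place would fall on each core, and whether it would sit with the sulfonyl or the sulfanyl member of each pair.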